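This account rests on a few compounds, and the source may have more. Where it says the series, first, only, none or still open, it means among the compounds named here.

Of the compounds shown here, two built on a shared core have been measured so far. Compound 1 `COc1ccccc1/C=C1\NS(=O)(=O)c2ccccc2C1=O` carries a 2-methoxyphenyl group, and in an assay for inhibition of alkaline phosphatase, tissue-nonspecific isozyme (Homo sapiens), read by spectrophotometry, with stated times of 10 min and 20 min (a lower number here means a stronger inhibitor, a higher number a weaker inhibitor), compound 1 gives 2590 nM. Compound 2 `O=C1/C(=C/c2ccc(Br)cc2)NS(=O)(=O)c2ccccc21` carries a 4-bromophenyl group instead, and in this assay compound 2 gives 1430 nM. Compound 2 thus holds the lower of the two numbers, but its gap to compound 1 lies within the scatter of repeated measurements, so the pair cannot be told apart with confidence. Within the data shown here, no two measured compounds differ in only one place, so no single structural step has yet been measured.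

Compound 3 `O=C1/C(=C/c2cccc(O)c2)NS(=O)(=O)c2ccccc21` is the compound still to be tested. It differs from compound 2 by 3-hydroxyphenyl in place of 4-bromophenyl on a double-bonded chain carbon bound to a double-bonded ring carbon. Among the measured compounds shown here, since no measured step of this kind exists, only a cautious expectation can be offered. The step is expected to be a 1.4-fold higher number from compound 2 to compound 3 (0.15 log units; within the scatter), which would leave the result close to compound 2 and likely not beyond the scatter. Compound 3 is therefore estimated at 2000 nM in this assay, with a plausible range from 700 nM to 6000 nM.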

Compound 3, half-maximal inhibitory concentration: 3570 nM
Compound 3: the middle estimate sits 1.8-fold (0.25 log units) below what was measured; measured number inside the range.
By their numbers in this assay, from the lowest: compounds 2, 1 and 3 (each within the scatter of the next, the first and the last beyond it).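

At the double-bonded chain carbon bound to a double-bonded ring carbon, this assay now gives the first measured single step, as 3-hydroxyphenyl in place of 4-bromophenyl brings a 2.5-fold higher number from compound 2 to compound 3 (0.40 log units; beyond the scatter), a modest change but one beyond the scatter. This shows that the number responds to the group at this place, which compounds 1 and 2 could not show, as their values lie within the scatter of each other; the response appears even though the two groups have the same heavy-atom count and the entering group alone carries a hydrogen-bond donor and acceptor. Nothing among the data shown explains the size or direction of this step.

The step exchanges the bromine for a hydroxyl group and moves the substituent from the 4 to the 3 position of the phenyl group, so the contributions of the atom and of its location remain inseparable. The compounds shown therefore leave open how 3-bromophenyl or 4-hydroxyphenyl would compare at this place, and how an amine or a carboxylic acid on the phenyl group would read in this assay.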